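The source may report more compounds than this note shows. Statements on the series, on what has been measured and on what is new or still open speak of the compounds shown alone.

Measured compounds:
compound 1, `Cc1nc(C)c([C@H](OC(C)(C)C)C(=O)O)c(N2CCC(C)(C)CC2)c1-c1ccc(OCCc2ccc(F)cc2F)cc1`: 1.08 h
compound 2, `Cc1nc(C)c([C@H](OC(C)(C)C)C(=O)O)c(N2CCC(C)(C)CC2)c1-c1ccc(OCCc2ccc(F)c(F)c2)cc1`: a limit of the assay, > 2 h

In an ADME assay on microsomes from liver (Homo sapiens) for metabolic stability, read by LC-MS, tested at 0.5 uM (on this read-out lower numbers stand for a shorter-lived compound and higher numbers for a longer-lived compound), compound 1 gives 1.08 h. For compound 2 only a limit is known, > 2 h, so compound 2 sits at the limit of > 2 h in this assay, at which 1 of the 2 values shown sits. Among the compounds with values here, the single measured step is an at least 1.8-fold higher number from compound 1 to compound 2 (0.26 log units; that floor lies within the scatter). Compound 3, `Cc1nc(C)c([C@H](OC(C)(C)C)C(=O)O)c(N2CCC(C)(C)CC2)c1-c1ccc(SCCc2ccc(F)cc2)cc1`, differs from compound 2 by (2-(4-fluorophenyl)ethyl)sulfanyl in place of 2-(3,4-difluorophenyl)ethoxy on an aromatic carbon. The measured step concerns the difluorophenyl alone and does not cover this change, so no direction beyond the scatter can be drawn from it. Compound 3 is therefore estimated at 1.5 h, expected between 0.7 h and 3 h. The expected step of an at least 1.3-fold lower number from compound 2 to compound 3 (0.12 log units; that floor lies within the scatter) reflects only that uncertainty.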

Compound 3, half-life: > 2 h
Compound 3 gave a limit, no number; the forecaster's own chance of this, stated with the estimate: 30%; middle value at least 1.3-fold (0.12 log units) from the limit.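

In this assay compound 3 gives > 2 h, which is a limit of the assay and not a number. A second chain on this aromatic carbon, para to a large group, thus reaches the limit: (2-(4-fluorophenyl)ethyl)sulfanyl joins 2-(3,4-difluorophenyl)ethoxy there, with an at least 1.8-fold higher number from compound 1 to compound 3 (0.26 log units; that floor lies within the scatter). The step between the two compounds at the limit cannot be read: the limit of > 2 h in this assay, at which 2 of the 3 values shown sit.

The sulfur and the fluorine pattern change together here, and a 2-(4-fluorophenyl)ethoxy group on the same carbon would separate them. From the compounds shown here alone, how long compound 2 and compound 3 last beyond the limit remains open.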